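The source may hold more compounds than are shown below. What is called first, only, known or untested is meant among the compounds shown, and "the series" means these compounds.

Working notes on the series, with the read-out taken from a toxicity assay on A549 cells (Homo sapiens) for cytotoxicity, read by CCK-8 assay; on this read-out lower numbers stand for higher toxicity in this test and higher numbers for lower toxicity in this test. In this assay compound 1 `COc1cccc2[nH]c(C(=O)N[C@@H](CC(C)C)C(=O)N[C@H](C=O)C[C@@H]3CCNC3=O)cc12` gives > 200000 nM, and this is a limit of the assay, not a number. Compound 2 `COc1cc(Cl)cc2[nH]c(C(=O)N[C@@H](CC(C)(C)C)C(=O)N[C@H](C#N)C[C@@H]3CCCNC3=O)cc12` gives > 200000 nM, which is also a limit. Among the measured compounds shown here, compound 1 therefore has no numeric standing, and no measured step is available to size a change.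

The next compound is compound 3 `COc1cccc2[nH]c(C(=O)N[C@@H](CC(C)C)C(=O)N[C@H](C#N)C[C@@H]3CCCNC3=O)cc12`, and the structural change from compound 1 is a group of 11 heavy atoms (8 carbon, 2 nitrogen, 1 oxygen; one six-membered non-aromatic ring with 1 hetero atom) in place of a group of 10 heavy atoms (7 carbon, 1 nitrogen, 2 oxygen; one five-membered non-aromatic ring with 1 hetero atom), on an amide-type nitrogen. On an amide-type nitrogen, a group with a six-membered non-aromatic ring replaces the 1-formyl-2-(2-oxopyrrolidin-3-yl)ethyl group.

In this assay, no step beyond the scatter is expected in either direction, on the strength of the limit of > 200000 nM in this assay, at which 2 of the 2 values shown sit. The expected change is a number no higher from compound 1 to compound 3 (the limit leaves the size open). Compound 3 is estimated at 200000 nM, with an expected range of 80000 nM to 300000 nM.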

Compound 3, half-maximal cytotoxic concentration: > 200000 nM
Compound 3: no number, only a limit (the forecaster's own chance of this, stated with the estimate: 85%); the middle value lies on the limit itself.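

No step from compound 1 to compound 3 can be read, because both values are limits, not numbers: the limit of > 200000 nM in this assay, at which 3 of the 3 values shown sit.

The compounds shown leave open at what concentration, if any, cytotoxicity appears, and whether the change on the amide-type nitrogen alters it.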